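Cytotoxicity on prostate cancer cells: a sulfonamide-to-aminopyrimidine swap

This account rests on a few compounds, and the source may have more. Where it says the series, first, only, none or still open, it means among the compounds named here.

The measured compounds, all tested in an ADME assay on PC-3 cells (Homo sapiens) for cytotoxicity, read by CCK-8 assay, with a stated time of 6 days; on this read-out lower numbers stand for stronger inhibition and higher numbers for weaker inhibition:
Compound 1 `CC(O)c1ccc(C(=O)N[C@@H](C)Cn2ccc(-c3ccc(C#N)c(Cl)c3)n2)cc1` gives > 30000 nM, which is a limit of the assay and not a number.
Compound 2 `CC(=O)c1ccc(S(=O)(=O)N[C@@H](C)Cn2ccc(-c3ccc(C#N)c(Cl)c3)n2)cc1` gives > 30000 nM, again a limit.
Compound 3 `C[C@@H](Cn1ccc(-c2ccc(C#N)c(Cl)c2)n1)NS(=O)(=O)c1cn(C)cn1` gives > 30000 nM, also a limit.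

All three share a core carrying a chlorinated benzonitrile on a pyrazole and differ only in the group on the side-chain nitrogen. Compound 3 therefore stands on the same footing as the other two: the limit of > 30000 nM in this assay, at which 3 of the 3 values shown sit, is all that is known of it. Among the measured compounds shown here, the only step between neighbouring compounds, a step that the two limits leave unreadable from compound 2 to compound 3, cannot be sized, since both ends are limits.

Compound 4 `C[C@@H](Cn1ccc(-c2ccc(C#N)c(Cl)c2)n1)Nc1nccc(Cl)n1` is the not yet measured member: it replaces (4-chloropyrimidin-2-yl in place of (1-methyl-1H-imidazol-4-yl)sulfonyl on an amine nitrogen), with the 4-chloropyrimidin-2-yl entering on an amine nitrogen whose other neighbours are a saturated chain carbon. For the measured compounds named here, no measured step bears on this change, and none of the measured values reaches a readable number. The expectation for compound 4 in this assay is thus no readable step, a number no higher from compound 3 to compound 4 (the limit leaves the size open), with the likeliest outcome being another limit. The estimate for compound 4 is 30000 nM, within 8000 nM to 100000 nM.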

Compound 4, half-maximal inhibitory concentration: > 30000 nM
Compound 4: no number, only a limit; the forecaster's own chance of this, stated with the estimate: 80%; the middle value sits exactly at the limit.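

In this assay compound 4 gives > 30000 nM, which is a limit of the assay and not a number. Among the compounds shown here, compound 3 also stands at a limit, so no step from compound 3 to compound 4 can be read. The compounds shown leave open which change to the shared core, if any, would give a readable number: the limit of > 30000 nM in this assay, at which 4 of the 4 values shown sit.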